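Swapping 2-methylphenyl for 4-methylphenyl on a shared core

A few compounds are considered here, and "the series" means these few. Any claim that something is new, unique, unknown or untested is made for them only; others in the source may bear on it.

In a physicochemical assay for solubility, read by HPLC, in phosphate buffer, with a stated time of 24 h, at pH 7.4, tested at 100 uM (a lower number here means a less soluble compound, a higher number a more soluble compound), compound 1 (`O=C(CCCCCNc1c(NCc2ccccc2)c(=O)c1=O)NO`) gives 75000000 nM while compound 2 (`C[C@H](Nc1c(NCCCCCC(=O)NO)c(=O)c1=O)c1ccccc1`) gives 73000000 nM and compound 3 (`Cc1ccccc1Nc1c(NCCCCCC(=O)NO)c(=O)c1=O`) gives 89000000 nM in the same measurement. These three numbers lie within the scatter of one another, so compound 3 holds no separate place among them. Compound 4 (`Cc1ccc(Nc2c(NCCCCCC(=O)NO)c(=O)c2=O)cc1`) has the same atoms as compound 3 joined differently, with 4-methylphenyl in place of 2-methylphenyl on a nitrogen on an aromatic ring. Within the data shown here, no measured step makes this exact change. Replacements on that nitrogen gave a 1.2-fold higher number from compound 1 to compound 3 (0.07 log units; within the scatter) and a 1.2-fold higher number from compound 2 to compound 3 (0.09 log units; within the scatter) in the series, and methyl in place of hydrogen on the chain carbon gave a 1.0-fold lower number from compound 1 to compound 2 (0.01 log units; within the scatter) as well. With all three steps inside the scatter, no step beyond the scatter is expected in this assay for this change, and neither direction is favoured. The estimate amounts to a 1.1-fold lower number from compound 3 to compound 4 (0.04 log units; within the scatter) as the expected shift. For compound 4 the estimated value is 82000000 nM with an expected range from 55000000 nM to 100000000 nM in this read-out.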

Compound 4, solubility: 8100000 nM
The estimate for compound 4 lay 10-fold (1.01 log units) above the measured number, outside the stated range (below it).
By their numbers in this assay, from the lowest: compound 4; then compounds 2, 1 and 3 (each within the scatter of the next).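

In this assay, the nitrogen on an aromatic ring had taken benzyl, 1-phenylethyl and 2-methylphenyl with every step inside the scatter, yet it proved sensitive to the change between two groups of the same atoms, with an 11-fold lower number from compound 3 to compound 4 (1.04 log units; beyond the scatter). The other two replacements on that nitrogen point the same way, with a 9.0-fold lower number from compound 2 to compound 4 (0.95 log units; beyond the scatter) and a 9.3-fold lower number from compound 1 to compound 4 (0.97 log units; beyond the scatter), so compound 4 stands apart from all three earlier compounds, which remain within the scatter of one another. Nothing available accounts for this difference.

The compounds shown leave open whether the lower number belongs to 4-methylphenyl alone or would also follow from 4-chlorophenyl or 4-methoxyphenyl on that nitrogen. They also leave open how unsubstituted phenyl there would compare with compound 3 and compound 4.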